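This account rests on a few compounds, and the source may have more. Where it says the series, first, only, none or still open, it means among the compounds named here.

Working notes on the series. Within the data shown here, in an ADME assay on microsomes from liver (Mus musculus) for metabolic stability, with a stated time of 10 min (on this read-out lower numbers stand for a less stable compound and higher numbers for a more stable compound), compound 2 `C[C@]1(c2ccc(F)cc2)CN(C(=O)C2CCN(C(=O)C(N)=O)CC2)C[C@H]1c1ccc(C(O)(C(F)(F)F)C(F)(F)F)cc1` gives 87%, the higher of the two numbers so far, against compound 1 `C[C@]1(c2ccc(F)cc2)CN(C(=O)NCc2ccncc2)C[C@H]1c1ccc(C(O)(C(F)(F)F)C(F)(F)F)cc1` at 1%. Compound 3 `COCC(=O)N1CCC(C(=O)N2C[C@@H](c3ccc(C(O)(C(F)(F)F)C(F)(F)F)cc3)[C@@](C)(c3ccc(F)cc3)C2)CC1` differs from compound 2 in one place, with methoxymethyl in place of carbamoyl on a carbonyl carbon. Among the measured compounds shown here, the only measured step is large: a number 86 percentage points higher from compound 1 to compound 2 (beyond the scatter). It swapped ((pyridin-4-yl)methyl)amino for the whole 1-(carbamoylcarbonyl)piperidin-4-yl, so it does not separate the part played by the carbamoyl. For the measured compounds named here, no measured pair isolates the present change, and the direction remains uncertain. Compound 3 keeps the rest of that larger replacement, so it is expected to stay closer to compound 2 than to compound 1, with some loss. The expected step is moderate and downward: a number 19 percentage points lower from compound 2 to compound 3 (beyond the scatter). For compound 3 the estimated value is 68%, within a range of 38% to 90%.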

Compound 3, percent of the compound remaining: 49%
Compound 3: the middle estimate sits 19 percentage points above what was measured, and the stated range covers the measured number.
By their numbers in this assay, from the lowest: compound 1; then compound 3; then compound 2.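

In this assay, the carbamoyl on this carbonyl carbon now has a contribution of its own: replacing it with methoxymethyl gives a number 38 percentage points lower from compound 2 to compound 3 (beyond the scatter) in the same piperidine-bearing setting. The rest of the larger replacement still retains part of the gain without the carbamoyl, with a number 48 percentage points higher from compound 1 to compound 3 (beyond the scatter) on exchanging ((pyridin-4-yl)methyl)amino for 1-((methoxymethyl)carbonyl)piperidin-4-yl. No supporting measurement available here explains the size of either step.

Carbamoyl carries one hydrogen-bond donor and methoxymethyl none, but this single pair cannot show whether that difference matters. As far as these compounds go, whether an aminomethyl group or a carboxylic acid on the same carbonyl carbon would sit nearer compound 2 or compound 3 remains open.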